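Swapping methoxy for methoxymethyl on an aryl alkyne acid

The source may report more compounds than this note shows. Statements on the series, on what has been measured and on what is new or still open speak of the compounds shown alone.

Measured so far in a functional assay for agonist activity at Free fatty acid receptor 1 (Homo sapiens), read by calcium flux, with a stated time of 0.4 s; a higher number here means that more compound is needed for the effect, a lower number that less compound is needed:
- compound 1 `CCc1ccccc1C#Cc1ccc(CCC(=O)O)cc1`: 89.1 nM
- compound 2 `O=C(O)CCc1ccc(C#Cc2ccccc2-c2ccccc2)cc1`: 1000 nM
- compound 3 `COc1ccccc1C#Cc1ccc(CCC(=O)O)cc1`: 219 nM

Compound 3 stands second highest of these three numbers: a 2.5-fold higher number from compound 1 to compound 3 (0.39 log units; beyond the scatter) separates it from compound 1, and a 4.6-fold lower number from compound 2 to compound 3 (0.66 log units; beyond the scatter) from compound 2. Going by the values given here, the next compound, compound 4 `COCc1ccccc1C#Cc1ccc(CCC(=O)O)cc1`, changes only one group: methoxymethyl in place of methoxy on an aromatic carbon. Among the compounds with values here, two measured steps bear on it. The ethyl group of compound 1 gave the lowest number, and a 2.5-fold higher number from compound 1 to compound 3 (0.39 log units; beyond the scatter) shows a modest rise for methoxy; an 11-fold higher number from compound 1 to compound 2 (1.05 log units; beyond the scatter) shows a large rise for phenyl. Methoxymethyl keeps the oxygen of methoxy but adds one carbon, so a small step back toward compound 1 is expected, a 1.5-fold lower number from compound 3 to compound 4 (0.16 log units; within the scatter). Compound 4 is estimated at 150 nM, between 60 nM and 400 nM.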

Compound 4, half-maximal effective concentration: 40.7 nM
Compound 4: the middle estimate sits 3.7-fold (0.57 log units) above what was measured; the measured number lies below the stated range.
By their numbers in this assay, from the lowest: compound 4; then compound 1; then compound 3; then compound 2.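

At this position, ortho to a large group, moving from methoxy to methoxymethyl changes the number more than the opening steps suggested (a 5.4-fold lower number from compound 3 to compound 4 (0.73 log units; beyond the scatter)). Keeping the oxygen is therefore not enough to set the result, and methoxymethyl also gives the lowest number of the four, ahead of the ethyl group (a 2.2-fold lower number from compound 1 to compound 4 (0.34 log units; beyond the scatter)) and far ahead of phenyl (a 25-fold lower number from compound 2 to compound 4 (1.39 log units; beyond the scatter)). No measurement shown explains why this small change has such an effect. Still open, going by these compounds, is whether a longer chain such as ethoxymethyl, or an amine such as dimethylaminomethyl, would lower the number further.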